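The compounds below may be only part of what the source reports. "The series", "measured", "known", "first", "only" and "open" are said of these compounds alone.

Measured compounds:
compound 1, `O=C1/C(=C/c2ccccc2F)CN(C(=S)SCc2cn(Cc3ccccc3Cl)nn2)C/C1=C\c1ccccc1F`, 46300 nM
compound 2, `Cc1ccc(/C=C2\CN(C(=S)SCc3cn(Cc4ccccc4F)nn3)C/C(=C\c3ccc(C)cc3)C2=O)cc1`, 80000 nM
compound 3, `O=C1/C(=C/c2ccccc2F)CN(C(=S)SCc2cn(Cc3ccccc3F)nn2)C/C1=C\c1ccccc1F`, > 80000 nM

In a functional assay on DU-145 cells (Homo sapiens) for cytotoxicity, read by MTT assay, with a stated time of 24 h (on this read-out lower numbers stand for stronger inhibition and higher numbers for weaker inhibition), compound 1 gives 46300 nM. Compound 2 gives 80000 nM. Compound 3 gives only a limit of the assay, > 80000 nM. For the measured compounds named here, the single change from compound 3 to compound 1, (chloro in place of fluoro on an aromatic carbon), produced an at least 1.7-fold lower number from compound 3 to compound 1 (0.23 log units; that floor lies within the scatter); the true size of that step is open because of the limit of > 80000 nM in this assay, at which 1 of the 3 values shown sits. Compound 4, `Cc1ccc(/C=C2\CN(C(=S)SCc3cn(Cc4ccccc4Cl)nn3)C/C(=C\c3ccc(C)cc3)C2=O)cc1`, is not yet measured. It stands to compound 2 as compound 1 stands to compound 3: the change is chloro in place of fluoro on an aromatic carbon, the same change at the same kind of place, while the difference between the two cores is not broken down here. Resting on an at least 1.7-fold lower number from compound 3 to compound 1 (0.23 log units; that floor lies within the scatter), the step from compound 2 to compound 4 is expected to be a 1.6-fold lower number from compound 2 to compound 4 (0.20 log units; within the scatter). Compound 4 is accordingly estimated at 50000 nM, between 20000 nM and 90000 nM.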

Compound 4, half-maximal inhibitory concentration: > 80000 nM
Compound 4 gave a limit, no number; the forecaster's own chance of this, stated with the estimate: 25%; middle value at least 1.6-fold (0.20 log units) from the limit.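

In this assay compound 4 gives only a limit of the assay, > 80000 nM. Putting chloro in place of fluoro gives a number no lower from compound 2 to compound 4 (the limit leaves the size open). This step therefore cannot be read as a size, so the change can be set side by side on the two cores only loosely: the same change on two cores in this assay, an at least 1.7-fold lower number (0.23 log units; that floor lies within the scatter) from compound 3 to compound 1 and a number no lower (the limit leaves the size open) from compound 2 to compound 4; the limit leaves it open whether they differ. This neither shows that the change carries from one core to the other nor shows that it fails to, and much of the series sits at the same edge of the assay: the limit of > 80000 nM in this assay, at which 2 of the 4 values shown sit.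

The benzyl groups shown carry only fluoro or chloro. On these data alone, it stays open whether a methoxy group or an amine at that place would give a readable number on either core.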